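Dihalophenyl versus methoxyphenyl on the chalcone carbonyl

The source may hold more compounds than are shown below. What is called first, only, known or untested is meant among the compounds shown, and "the series" means these compounds.

Two compounds of the series carry a measurement in a functional assay on M14 cells (Homo sapiens) for cytotoxicity, read by sulforhodamine B assay, with a stated time of 48 h, tested at 100 uM; on this read-out higher numbers stand for a weaker effect at the one concentration tested and lower numbers for a stronger effect. Compound 1 `COc1cc(-c2cc(/C=C/C(=O)c3ccc(Cl)c(Cl)c3)[nH]n2)cc(OC)c1OC` gives 20% in this assay. Compound 2 `COc1ccc(C(=O)/C=C/c2cc(-c3cc(OC)c(OC)c(OC)c3)n[nH]2)cc1` gives -7% in this assay, the lowest of the two numbers; the nearest is compound 1, and the step of a number 27 percentage points lower from compound 1 to compound 2 (beyond the scatter) was beyond the scatter.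

Compound 3 `COc1cc(-c2cc(/C=C/C(=O)c3ccc(F)c(F)c3)[nH]n2)cc(OC)c1OC` has not been measured. It differs from compound 2 by 3,4-difluorophenyl in place of 4-methoxyphenyl on a carbonyl carbon. For the measured compounds named here, the one step that bears on this change runs the other way in compound 1, where the aryl on the carbonyl carbon was a dihalophenyl and the number stood higher: a number 27 percentage points lower from compound 1 to compound 2 (beyond the scatter). Going by the values given here, compound 3 returns a dihalophenyl to that position, with fluorine rather than chlorine, so the step from compound 2 is expected to go upward, toward the number of compound 1 but not necessarily all the way, since no fluorine analogue has been measured here; the estimated step is a number 19 percentage points higher from compound 2 to compound 3 (beyond the scatter). Compound 3 is therefore expected to give 12% in this assay, within a range from -10% to 35%.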

Compound 3, a percentage reported as activity, at one concentration (the size of the read-out at that concentration, not a potency): -38%
Estimate against measurement, compound 3: 50 percentage points above, outside the stated range (below it).
By their numbers in this assay, from the lowest: compound 3; then compound 2; then compound 1.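

In this assay, the aryl group on a carbonyl carbon does not behave as a simple choice between dihalophenyl and methoxyphenyl: the step for 3,4-difluorophenyl in place of 4-methoxyphenyl is a number 31 percentage points lower from compound 2 to compound 3 (beyond the scatter), so the 4-methoxyphenyl of compound 2 stands between two dihalophenyl groups in the order of the three numbers. The identity of the halogen therefore matters at this position, with the step for 3,4-difluorophenyl in place of 3,4-dichlorophenyl being a number 58 percentage points lower from compound 1 to compound 3 (beyond the scatter), and the earlier pair could not show this because it held only one dihalophenyl. Nothing on hand accounts for the order of the three groups.

With only one pair of halogens and one methoxyphenyl in view, the compounds shown leave open whether a single halogen, as in 4-fluorophenyl, or a group of another kind, such as 4-aminophenyl or 4-carboxyphenyl, would follow the difluoro or the dichloro result. Each number also comes from a single concentration, so these compounds leave open whether the same order of stronger and weaker effect would hold at other concentrations.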